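A few compounds are considered here, and "the series" means these few. Any claim that something is new, unique, unknown or untested is made for them only; others in the source may bear on it.

Measured in a functional assay on Jurkat cells (Homo sapiens); on this read-out lower numbers stand for stronger inhibition and higher numbers for weaker inhibition:
- Compound 1 `CC(C)[C@H](NC(=O)COc1cccc2ccccc12)C(=O)N[C@@H](CC(=O)O)C(=O)COc1ccc(-c2ccccc2)cc1`: 87900 nM
- Compound 2 `CC(C)[C@H](NC(=O)COc1cccc2ccccc12)C(=O)N[C@@H](CC(=O)O)C(=O)COc1c(F)cccc1F`: 2040 nM

Going by the values given here, compound 2 holds the lower of these two numbers, and the only measured step is a 43-fold lower number from compound 1 to compound 2 (1.63 log units; beyond the scatter). Compound 3 `CC(C)[C@H](NC(=O)COc1cccc2ccccc12)C(=O)N[C@@H](CC(=O)O)C(=O)COc1cc(F)cc(F)c1F` differs from compound 2 in one group: 2,3,5-trifluorophenyl in place of 2,6-difluorophenyl on an oxygen on a saturated carbon. The measured step removed 4-phenylphenyl, whereas this change swaps one fluorinated phenyl group for another, so it offers only a loose guide. In this assay, a small move towards a lower number is expected, probably not beyond the scatter. The expected change is a 1.7-fold lower number from compound 2 to compound 3 (0.23 log units; within the scatter). The estimate for compound 3 is 1200 nM, with an expected range of 300 nM to 5000 nM.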

Compound 3, half-maximal inhibitory concentration: 30000 nM
The estimate for compound 3 lay 25-fold (1.40 log units) below the measured number, outside the stated range (above it).
By their numbers in this assay, from the lowest: compound 2; then compound 3; then compound 1.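

In this assay, the fluorinated phenyl groups on this oxygen on a saturated carbon are not interchangeable: 2,3,5-trifluorophenyl in place of 2,6-difluorophenyl gives a large step (a 15-fold higher number from compound 2 to compound 3 (1.17 log units; beyond the scatter)). Compound 3 keeps only a modest advantage over the 4-phenylphenyl compound (a 2.9-fold lower number from compound 1 to compound 3 (0.47 log units; beyond the scatter)), so most of the earlier gain is lost with this one change. Nothing available explains this loss.

The change alters both the number and the placement of the fluorines, and these two compounds cannot separate those effects. As far as these compounds go, how unsubstituted phenyl or 2,6-dichlorophenyl would compare at this position remains open.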